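The source may report more compounds than this note shows. Statements on the series, on what has been measured and on what is new or still open speak of the compounds shown alone.

Three compounds of the series have a number in a physicochemical assay for solubility, using the shake flask method, with a stated time of 48 h, at pH 6.5; a higher number here means a more soluble compound, a lower number a less soluble compound. Compound 1 `N#Cc1ccccc1-c1cc(-c2cc(Cl)cc(OCCC(F)(F)F)c2)c(=O)n(-c2cccnc2)c1` gives 25 ug/mL. Compound 2 `Cc1ocnc1COc1cc(Cl)cc(-c2cc(-c3ccccc3C#N)cn(-c3cccnc3)c2=O)c1` gives 13.1 ug/mL, and compound 3 `Cc1ocnc1COc1cc(Cl)cc(-c2cc(-c3c[nH]c(=O)[nH]c3=O)cn(-c3cccnc3)c2=O)c1` gives 7.6 ug/mL. Compound 3 holds the lowest of the three numbers; the nearest is compound 2, the furthest compound 1, the two steps being a 1.9-fold lower number from compound 1 to compound 2 (0.28 log units; within the scatter) and a 1.7-fold lower number from compound 2 to compound 3 (0.24 log units; within the scatter). Compound 4 `Cc1ncoc1COc1cc(Cl)cc(-c2cc(-c3c[nH]c(=O)[nH]c3=O)cn(-c3cccnc3)c2=O)c1` differs from compound 3 only in one place: 4-methyl-1,3-oxazol-5-yl in place of 5-methyl-1,3-oxazol-4-yl on a saturated chain carbon bound to an oxygen on an aromatic ring. Within the data shown here, the one measured step at that place, a 1.9-fold lower number from compound 1 to compound 2 (0.28 log units; within the scatter), stayed within the scatter, and no measured step exchanges the two oxazole isomers. In this assay no step beyond the scatter is therefore expected, and the step of a 1.1-fold lower number from compound 3 to compound 4 (0.04 log units; within the scatter) is expected to be small. Compound 4 is estimated at 7 ug/mL, within 3.5 ug/mL to 15 ug/mL.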

Compound 4, solubility: 168 ug/mL
Estimate against measurement, compound 4: 24-fold (1.38 log units) below; the whole stated range lies below it.
By their numbers in this assay, from the lowest: compounds 3, 2 and 1 (each within the scatter of the next, the first and the last beyond it); then compound 4.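

In this assay the exchange of the two oxazole isomers on a saturated chain carbon bound to an oxygen on an aromatic ring gives a 22-fold higher number from compound 3 to compound 4 (1.34 log units; beyond the scatter) and so shows that this position responds strongly to the arrangement of the ring alone, with the same atoms and the same donor and acceptor counts on both sides. Nothing in a 1.9-fold lower number from compound 1 to compound 2 (0.28 log units; within the scatter) at this place hinted at such sensitivity. No measurement at hand accounts for the step.

From the compounds shown here alone, whether the same isomer exchange gives a step of this size on the core of compound 2 stays open. So does how an amine or a carboxylic acid at this place would stand against 4-methyl-1,3-oxazol-5-yl.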